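Cytotoxicity on Vero Cells: From Nitrophenyl to Chlorophenyl

The compounds below may be only part of what the source reports. "The series", "measured", "known", "first", "only" and "open" are said of these compounds alone.

Measured so far:
compound 1 `CCCCc1nc(Cl)c(C2NC(=O)NC(C)=C2C(=O)Nc2ccccc2C)[nH]1`: "not determined" (no result reported)
compound 2 `CCCCc1nc(Cl)c(C2NC(=O)NC(C)=C2C(=O)Nc2ccc([N+](=O)[O-])cc2)[nH]1`: > 10 ug/mL

Of the compounds shown here, two sharing one core have been tested in an ADME assay on Vero cells (Chlorocebus sabaeus) for cytotoxicity, read by MTT assay, with a stated time of 72 h; on this read-out higher numbers stand for weaker inhibition and lower numbers for stronger inhibition. For compound 1 no result was reported, so "not determined" (no result reported) stands in its place. For compound 2 the read-out is only a limit of the assay, not a number: in this assay compound 2 gives > 10 ug/mL. That limit is the limit of > 10 ug/mL in this assay, at which 1 of the 2 values shown sits, so compound 2 is placed at the edge of what the assay can resolve rather than at a measured point. For the measured compounds named here, no step between two measured compounds exists here, since only one of the two carries a value at all.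

The compound to be measured next is compound 3 `CCCCc1nc(Cl)c(C2NC(=O)NC(C)=C2C(=O)Nc2ccccc2Cl)[nH]1`. It differs from compound 2 by 2-chlorophenyl in place of 4-nitrophenyl on an amide-type nitrogen. Going by the values given here, with no measured step to lean on, the expectation is that compound 3 stays near compound 2, with a step that the limit leaves unreadable from compound 2 to compound 3 that is expected not to exceed the scatter. Compound 3 is therefore estimated at 15 ug/mL, within 5 ug/mL to 50 ug/mL, and it is expected that the assay may again report only a limit.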

Compound 3, half-maximal inhibitory concentration: 7.6 ug/mL
Estimate against measurement, compound 3: 2.0-fold (0.30 log units) above; the range from low to high includes it.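

In this assay, for the compounds shown here, compound 3 gives 7.6 ug/mL, the first actual number for the shared core, so with 2-chlorophenyl in place of 4-nitrophenyl on the amide-type nitrogen, the read-out falls within the range the assay can resolve. The change reads as an at least 1.3-fold lower number from compound 2 to compound 3 (0.11 log units; that floor lies within the scatter), and this is only a floor, so the real step could be very small or much larger. The size of the step stays open because one of its two ends is not a number: the limit of > 10 ug/mL in this assay, at which 1 of the 3 values shown sits.

Both the substituent on the aromatic ring and its place on that ring differ between 4-nitrophenyl and 2-chlorophenyl, so these compounds cannot show which of the two matters, and neither compound 1, with no result, nor any other compound shown helps to separate them. On these data alone, it also remains open how a plain phenyl group, or a phenyl ring carrying an amine or a carboxylic acid, would behave on the same nitrogen in this assay.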